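Kinetic solubility notes on a shared-core series

The source may hold more compounds than are shown below. What is called first, only, known or untested is meant among the compounds shown, and "the series" means these compounds.

Measured so far:
compound 1 `CCC/N=C1\S/C(=C\c2ccc(C(=O)O)cc2)C(=O)N1c1ccccc1C`: 163000 nM
compound 2 `CCC/N=C1\S/C(=C\c2ccc(C(=O)NCC(=O)N(C)C)cc2)C(=O)N1c1ccccc1O`: 219000 nM

In a physicochemical assay for solubility, read by nephelometry, measured as kinetic solubility (on this read-out higher numbers stand for higher solubility and lower numbers for lower solubility), compound 2 gives 219000 nM, the higher of the two numbers shown, yet compound 1 with 163000 nM lies within the scatter of it, so no order between the two is claimed. Compound 3 `CCC/N=C1\S/C(=C\c2ccc(CCC(=O)OC)cc2)C(=O)N1c1ccccc1O` is not yet measured. It differs from compound 2 in one place: 2-(methoxycarbonyl)ethyl in place of ((dimethylcarbamoyl)methyl)carbamoyl on an aromatic carbon. Among the compounds with values here, no measured pair shows this change, so the step is a guess. A fall beyond the scatter is expected, a 2.4-fold lower number from compound 2 to compound 3 (0.39 log units; beyond the scatter). Compound 3 is estimated at 90000 nM, between 30000 nM and 220000 nM.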

Compound 3, solubility: 79000 nM
Compound 3: middle estimate off by 1.1-fold (0.06 log units), on the high side; the measured number falls inside the stated range.
By their numbers in this assay, from the lowest: compound 3; then compounds 1 and 2 (each within the scatter of the next).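

Within the data shown here, at this aromatic carbon, para to a large group, 2-(methoxycarbonyl)ethyl in place of ((dimethylcarbamoyl)methyl)carbamoyl gives the first single-place step in this assay: a 2.8-fold lower number from compound 2 to compound 3 (0.44 log units; beyond the scatter). The group at this position can therefore shift the read-out beyond the scatter, which compounds 1 and 2, differing in more than one place, could not show. No measurement shown here bears on the cause of this step.

From the compounds shown here alone, the heavy-atom count and the hydrogen-bond donor count change together in this one step, so which of them matters stays open. Going by these compounds, how an amine or a longer ester chain on this carbon would read against compound 2 also stays open.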